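A few compounds are considered here, and "the series" means these few. Any claim that something is new, unique, unknown or untested is made for them only; others in the source may bear on it.

Values measured in a functional assay on MDA-MB-231 cells (Homo sapiens) for antiproliferative activity, read by MTT assay, with a stated time of 48 h; a lower number here means a stronger inhibitor, a higher number a weaker inhibitor:
Compound 1 `O=C(CCCCCC(=O)Nc1nnc(-c2cccnc2)s1)NO`: 11700 nM
Compound 2 `O=C(CCCCCCC(=O)Nc1nnc(-c2ccncc2)s1)NO`: 4690 nM
Compound 3 `O=C(CCCCCCC(=O)Nc1nnc(-c2cccs2)s1)NO`: 1210 nM

Of these three, compound 3 has the lowest number at 1210 nM, clear of both others by more than the scatter. The next change leads to compound 4 `O=C(CCCCCCC(=O)Nc1nnc(-c2cccnc2)s1)NO`, in which pyridin-3-yl takes the place of thiophen-2-yl on an aromatic carbon: pyridin-3-yl in place of thiophen-2-yl on an aromatic carbon.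

Among the measured compounds shown here, no measured step covers this exact exchange. The nearest is a 3.9-fold lower number from compound 2 to compound 3 (0.59 log units; beyond the scatter), a modest change beyond the scatter, in which thiophen-2-yl replaced pyridin-4-yl on the same chain. Run in reverse and with the other pyridinyl group, that step points to a rise of similar size in this assay, though the transfer from one pyridinyl group to the other is untested. Compound 1 does carry pyridin-3-yl and reads 11700 nM, but its chain differs, so it gives only a loose upper guide. The expected change is a 3.7-fold higher number from compound 3 to compound 4 (0.57 log units; beyond the scatter), and this size is an estimate. For compound 4 the estimated value is 4500 nM, with an expected range from 2000 nM to 10000 nM.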

Compound 4, half-maximal inhibitory concentration: 1870 nM
The estimate for compound 4 lay 2.4-fold (0.38 log units) above the measured number; the measured number lies below the stated range.
By their numbers in this assay, from the lowest: compounds 3 and 4 (each within the scatter of the next); then compound 2; then compound 1.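

In this assay the exchange at this aromatic carbon of the shared core gives a 1.5-fold higher number from compound 3 to compound 4 (0.19 log units; within the scatter) and so, at this chain length, pyridin-3-yl and thiophen-2-yl cannot be told apart, even though one is a six-membered ring and the other a five-membered ring. The pyridinyl groups themselves are not interchangeable at this place, since the change of attachment gives a 2.5-fold lower number from compound 2 to compound 4 (0.40 log units; beyond the scatter) and the earlier gap between pyridin-4-yl and thiophen-2-yl therefore does not hold for pyridin-3-yl. With pyridin-3-yl kept in place, the chain also counts, as (hydroxycarbamoyl)methyl in place of hydroxycarbamoyl gives a 6.3-fold lower number from compound 1 to compound 4 (0.80 log units; beyond the scatter) and this is a larger step than either exchange of the aromatic group at this position.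

Nothing available explains why these steps have the sizes they do. The compounds shown leave open how a phenyl or pyridin-2-yl group would read at this aromatic carbon, and whether a still longer chain ending in the same hydroxycarbamoyl group would continue the step seen with the chain change.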